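From Bromo to Benzyl on a Shared Core

The source may report more compounds than this note shows. Statements on the series, on what has been measured and on what is new or still open speak of the compounds shown alone.

Among the measured compounds shown here, in a physicochemical assay for lipophilicity, at pH 7.4 (a higher number here means a more lipophilic compound, a lower number a more polar compound), compound 1 (`COc1ccc2[nH]c(C)c(Br)c(=O)c2c1`) gives 1.62 and stands highest of the two numbers so far, with compound 2 (`Cc1ccc2[nH]c(C)c(Br)c(=O)c2c1`) at 1.07 as its only neighbour. Compound 3 (`COc1ccc2[nH]c(C)c(Cc3ccccc3)c(=O)c2c1`) has benzyl in place of bromo on an aromatic carbon and otherwise keeps the core of compound 1. For the measured compounds named here, the sole measured step, a number 0.55 log units lower from compound 1 to compound 2 (beyond the scatter) with methyl in place of methoxy, lies at a different place and involves neither bromo nor benzyl. It therefore offers only a rough scale for this assay and no direct guide. Judged from the structural change alone, a rise clearly larger than that step is expected, with wide uncertainty. The estimated step is a number 1.08 log units higher from compound 1 to compound 3 (beyond the scatter) as the middle expectation. For compound 3 the estimated value is 2.7 with 2.1 to 3.3 as the expected range.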

Compound 3, distribution coefficient: 2.53
For compound 3 the middle estimate is 0.17 log units above the measured one; the range from low to high includes it.
By their numbers in this assay, from the lowest: compound 2; then compound 1; then compound 3.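

The position that carries bromo in compound 1 now has a measured step of its own, whereas the earlier step lay at a different place on the shared core. In this assay, benzyl in place of bromo gives a number 0.91 log units higher from compound 1 to compound 3 (beyond the scatter), beyond the scatter, as 7 heavy atoms and one six-membered aromatic ring of carbon only replace a single bromine, with no hydrogen-bond donors or acceptors and no net charge on either group. No supporting measurement accompanies this result to say why the number moves with this exchange.

With only bromo and benzyl at this position, the compounds leave open whether the rise tracks the aromatic ring or simply the carbon count, which a longer chain or a cyclohexylmethyl group could separate. They also leave open how an amine or a carboxylic acid at this position would read in this assay, and whether the benzyl step would hold with methyl in place of methoxy.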